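The compounds below may be only part of what the source reports. "The series", "measured", "known", "first", "only" and "open" are said of these compounds alone.

In an ADME assay on microsomes from liver (Homo sapiens) for metabolic stability, read by LC-MS, tested at 1 mM (on this read-out lower numbers stand for a shorter-lived compound and higher numbers for a longer-lived compound), compound 1 (`N#Cc1ccc(F)cc1Cn1c(N2CCC[C@@H](N)C2)nc2cc[nH]c2c1=O`) gives 3.33 h, compound 2 (`CC(C)S(=O)(=O)c1ccc(-c2c[nH]c3c(=O)n(Cc4cc(F)ccc4C#N)c(N4CCC[C@@H](N)C4)nc23)cc1`) gives 0.722 h and compound 3 (`N#Cc1ccc(F)cc1Cn1c(N2CCC[C@@H](N)C2)nc2c(-c3ccsc3)c[nH]c2c1=O`) gives 2.67 h. Compound 3 therefore stands level with compound 1, and both lie above compound 2. Thiophen-3-yl in place of hydrogen gives a 1.2-fold lower number from compound 1 to compound 3 (0.10 log units; within the scatter), while 4-(isopropylsulfonyl)phenyl in place of hydrogen gives a 4.6-fold lower number from compound 1 to compound 2 (0.66 log units; beyond the scatter). Compound 4 (`CS(=O)(=O)c1cccc(-c2c[nH]c3c(=O)n(Cc4cc(F)ccc4C#N)c(N4CCC[C@@H](N)C4)nc23)c1`) carries 3-(methylsulfonyl)phenyl in place of thiophen-3-yl on an aromatic carbon. The closest guide is the step of a 3.7-fold higher number from compound 2 to compound 3 (0.57 log units; beyond the scatter), which this change roughly reverses, although the two sulfonyl-bearing groups are not the same. A modest fall is therefore expected, a 2.7-fold lower number from compound 3 to compound 4 (0.43 log units; beyond the scatter). For compound 4 the estimated half-life is 1 h, with an expected range of 0.45 h to 2.2 h.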

Compound 4, half-life: > 3.33 h
Compound 4 gave a limit, no number; the forecaster's own chance of this, stated with the estimate: 2%; middle value at least 3.3-fold (0.52 log units) from the limit.
By their numbers in this assay, from the lowest: compound 2; then compounds 3 and 1 (each within the scatter of the next).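

Compound 4 carries a limit, not a number: the limit of > 3.33 h in this assay, at which 1 of the 4 values shown sits. A sulfonyl-bearing phenyl on this aromatic carbon therefore need not bring the short half-life of compound 2, with an at least 4.6-fold higher number from compound 2 to compound 4 (0.66 log units; beyond the scatter). Against thiophen-3-yl the change gives an at least 1.2-fold higher number from compound 3 to compound 4 (0.09 log units; that floor lies within the scatter). Against hydrogen it gives a number no lower from compound 1 to compound 4 (the limit leaves the size open), and the size of that step cannot be read.

The compounds shown leave open whether the methyl or isopropyl on the sulfonyl, or the sulfonyl's position on the phenyl, separates compound 2 from compound 4. From the compounds shown here alone, how a phenyl bearing a carboxylic acid or an amine would behave also stays open.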